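Amino for methyl on the aryl ring of compound 1

The source may report more compounds than this note shows. Statements on the series, on what has been measured and on what is new or still open speak of the compounds shown alone.

Three compounds of the shared core have numbers in an assay on isolated protein for inhibition of acid-sensing ion channel 3 (Homo sapiens), read by patch clamp; a lower number here means a stronger inhibitor, a higher number a weaker inhibitor. Compound 1 `Cc1cc(Cl)cc(-c2cc3cc(C(=N)N)ccc3[nH]2)c1` gives 51000 nM and holds the lowest of the three numbers. Compound 2 `N=C(N)c1ccc2[nH]c(-c3cc(Cl)cc(Cl)c3Cl)cc2c1` gives 135000 nM, a higher number than compound 1 by more than the scatter. Compound 3 `N=C(N)c1ccc2[nH]c(-c3cc(Cl)nc(Cl)c3)cc2c1` gives 291000 nM, the highest of the three and again beyond the scatter from compound 1.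

Compound 4 `N=C(N)c1ccc2[nH]c(-c3cc(N)cc(Cl)c3)cc2c1` is not yet measured. It differs from compound 1 in one place: amino in place of methyl on an aromatic carbon of a six-membered aromatic ring of carbon only. Among the compounds with values here, no measured pair shows this exchange, so its size is not known from the series. The expectation is a small step from compound 1 to compound 4, within or only just beyond the scatter, with no clear direction. The estimate for compound 4 in this assay is 60000 nM, in a range from 20000 nM to 200000 nM. The step this estimate means is expected as a 1.2-fold higher number from compound 1 to compound 4 (0.07 log units; within the scatter).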

Compound 4, half-maximal inhibitory concentration: 95000 nM
Estimate against measurement, compound 4: 1.6-fold (0.20 log units) below, within the range that was stated.
By their numbers in this assay, from the lowest: compounds 1, 4 and 2 (each within the scatter of the next, the first and the last beyond it); then compound 3.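

In this assay, within the data shown here, amino in place of methyl on this aromatic carbon gives a 1.9-fold higher number from compound 1 to compound 4 (0.27 log units; within the scatter) and is the first single-place step. The position therefore takes a nitrogen for a carbon, with the hydrogen-bond donor and acceptor counted for amino, without a change that can be told from the scatter. Nothing at hand bears on the reason for this step.

As far as these compounds go, whether the same holds for a hydroxyl, a methoxy, an acetamide or a dimethylamino group on this carbon stays open. Also open is what this one step says about the chloro group that compound 1 and compound 4 share, since no compound shown changes that group alone.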